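Swapping Benzyl for Phenyl on a Ring Nitrogen

The source may hold more compounds than are shown below. What is called first, only, known or untested is meant among the compounds shown, and "the series" means these compounds.

Measured compounds, in an assay on cells for inhibition of thyroid peroxidase (Homo sapiens), with stated times of 10 min and 15 min; a lower number here means a stronger inhibitor, a higher number a weaker inhibitor:
Compound 1 `Nc1cc(Cc2ccn(Cc3cccc(-c4ccccc4)c3)n2)c2nn[nH]c2n1` gives 1100 nM.
Compound 2 `Nc1cc(Cc2ccn(Cc3cccc(Oc4cccc5c4CNC5)c3)n2)c2nn[nH]c2n1` gives 1700 nM.
Compound 3 `Nc1cc(Cc2ccn(Cc3ccccc3)n2)c2nn[nH]c2n1` gives 2300 nM.

Compound 3 gives the highest of the three numbers. Its nearest neighbour is compound 2, through the step of a 1.4-fold higher number from compound 2 to compound 3 (0.13 log units; within the scatter). The step of a 2.1-fold higher number from compound 1 to compound 3 (0.32 log units; beyond the scatter) is larger. Both of these steps keep the benzyl group in place and only add or remove a group on its outer ring, and even the larger addition moved the number only modestly.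

Compound 4 `Nc1cc(Cc2ccn(-c3ccccc3)n2)c2nn[nH]c2n1` has not yet been measured. It differs from compound 3 in one place: phenyl in place of benzyl on an aromatic nitrogen. For the measured compounds named here, no measured step touches this attachment itself; the measured steps only decorate the benzyl ring, so they bear on the new change only indirectly, and no firm direction follows from them. The step of a 1.2-fold higher number from compound 3 to compound 4 (0.09 log units; within the scatter) is expected to stay within the scatter. Compound 4 is therefore expected to give about 2800 nM in this assay, with a range from 1200 nM to 7000 nM.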

Compound 4, half-maximal inhibitory concentration: 640 nM
Compound 4: the middle estimate sits 4.4-fold (0.64 log units) above what was measured; the measured number lies below the stated range.
By their numbers in this assay, from the lowest: compounds 4, 1, 2 and 3 (each within the scatter of the next, the first and the last beyond it).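

The group on this ring nitrogen matters more than the earlier changes to the outer ring of the benzyl group suggested: in this assay, replacing benzyl with phenyl gives a 3.6-fold lower number from compound 3 to compound 4 (0.56 log units; beyond the scatter), a step beyond the scatter. The earlier step beyond the scatter, a 2.1-fold higher number from compound 1 to compound 3 (0.32 log units; beyond the scatter), had the lower number on the larger compound 1, whereas here the lower number comes with the smaller group, so among these compounds a lower number does not depend on adding size. Nothing available here explains why phenyl gives a lower number than benzyl at this position.

Going by these compounds, it remains open whether a second phenyl or an aryl ether on the phenyl of compound 4 would shift the number as it did on benzyl. Also open, on these data alone, is how a methyl group, a longer phenethyl chain or a pyridine ring would compare on this nitrogen.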